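Notes: methyl to pyridin-3-yl on the carbonyl carbon

The compounds below may be only part of what the source reports. "The series", "measured", "known", "first", "only" and "open" are said of these compounds alone.

Among the compounds with values here, in a functional assay with Oryctolagus cuniculus as the target (a lower number here means a stronger inhibitor, a higher number a weaker inhibitor), compound 3 (`COc1ccc(-c2nc(CNC(C)=O)sc2-c2ccc(OC)cc2)cc1`) gives 15 nM as the lowest number so far. Compound 1 (`C/N=C(/NC)Nc1nc(-c2ccc(OC)cc2)c(-c2ccc(OC)cc2)s1`) gives 970 nM in the same read-out. Compound 2 (`COc1ccc(-c2nc(/N=C(\N)[N+]3(C)CCCCC3)sc2-c2ccc(OC)cc2)cc1`) gives > 1000 nM as a limit of the assay. Compound 4 (`COc1ccc(-c2nc(CNC(=O)c3cccnc3)sc2-c2ccc(OC)cc2)cc1`) has pyridin-3-yl in place of methyl on a carbonyl carbon. The measured steps (a 65-fold lower number from compound 1 to compound 3 (1.81 log units; beyond the scatter) and an at least 66-fold lower number from compound 2 to compound 3 (1.82 log units; beyond the scatter)) are large, yet both exchange the whole group on the aromatic carbon, and neither isolates the group on the carbonyl carbon. They give no direct size for this change, so only a moderate rise in the number is expected (a 3.3-fold higher number from compound 3 to compound 4 (0.52 log units; beyond the scatter)). For compound 4 the estimated value is 50 nM with 10 nM to 300 nM as its range.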

Compound 4, half-maximal inhibitory concentration: 25 nM
The estimate for compound 4 lay 2.0-fold (0.30 log units) above the measured number; the range from low to high includes it.
By their numbers in this assay, from the lowest: compounds 3 and 4 (each within the scatter of the next); then compound 1. At a limit, above all of these: compound 2.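

Putting pyridin-3-yl in place of methyl on the carbonyl carbon in this assay gives a small step (a 1.7-fold higher number from compound 3 to compound 4 (0.22 log units; within the scatter)), so this position takes the aromatic ring with no change beyond the scatter. The number stays far lower than for the groups on the aromatic carbon in compound 1 (a 39-fold lower number from compound 1 to compound 4 (1.59 log units; beyond the scatter)) and compound 2 (an at least 40-fold lower number from compound 2 to compound 4 (1.60 log units; beyond the scatter)). The value of compound 2 is a limit of the assay: the limit of > 1000 nM in this assay, at which 1 of the 4 values shown sits.

On these data alone, how phenyl, a carboxylic acid or a longer alkyl chain on the carbonyl carbon would read in this assay stays open.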